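The compounds below may be only part of what the source reports. "The series", "measured", "known", "first", "only" and "open" are said of these compounds alone.

Measured compounds:
- compound 1, `COc1cc(Cl)cc(-c2nn(-c3cccc(NC(=O)Nc4ccc(Cl)c(C(F)(F)F)c4)c3)cc2-c2ccncc2)c1`: 93%
- compound 2, `COc1cc(Cl)cc(-c2nn(-c3cccc(NC(=O)Nc4cc(C(F)(F)F)cc(C(F)(F)F)c4)c3)cc2-c2ccncc2)c1`: 92%
- compound 3, `COc1cc(Cl)cc(-c2nn(-c3cccc(NC(=O)Nc4ccc(Cl)c(Cl)c4)c3)cc2-c2ccncc2)c1`: 97%

These three compounds share one core and differ only in the substituted phenyl ring that sits on the urea nitrogen. In a functional assay on UACC-62 cells (Homo sapiens) for inhibition, read by sulforhodamine B assay, with a stated time of 48 h, tested at 0.1 uM (on this read-out lower numbers stand for a stronger effect and higher numbers for a weaker effect at the one concentration tested), compound 3 gives 97%, the highest of the three numbers, yet compound 1 with 93% and compound 2 with 92% lie within the scatter of it, so the three cannot be told apart on these numbers. Among the compounds with values here, the only single-point step measured, a number 4 percentage points higher from compound 1 to compound 3 (within the scatter), is within the scatter as well.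

Compound 4, `COc1cc(Cl)cc(-c2nn(-c3cccc(NC(=O)Nc4cccc(C(F)(F)F)c4)c3)cc2-c2ccncc2)c1`, is not yet measured. It differs from compound 3 by 3-(trifluoromethyl)phenyl in place of 3,4-dichlorophenyl on an amide-type nitrogen. This change is related to the measured step in that it again swaps a chloro for a trifluoromethyl, and at the same time removes one chloro. Within the data shown here, the measured step of a number 4 percentage points higher from compound 1 to compound 3 (within the scatter) shows that a chloro-for-trifluoromethyl exchange on this ring left the read-out within the scatter; for removing a chloro there is no measured step. The expected step of a number 3 percentage points lower from compound 3 to compound 4 (within the scatter) is therefore small, with no direction beyond the scatter. Compound 4 is estimated at 94%, in the range 84% to 103%.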

Compound 4, a percentage reported as activity, at one concentration (the size of the read-out at that concentration, not a potency): 96%
The estimate for compound 4 lay 2 percentage points below the measured number, within the range that was stated.
By their numbers in this assay, from the lowest: compounds 2, 1, 4 and 3 (each within the scatter of the next).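

In this assay, putting 3-(trifluoromethyl)phenyl in place of 3,4-dichlorophenyl on the amide-type nitrogen gives a number 1 percentage points lower from compound 3 to compound 4 (within the scatter). Two further comparisons are new. Each simply removes a group, leaving hydrogen on the aromatic carbon: losing a trifluoromethyl gives a number 4 percentage points higher from compound 2 to compound 4 (within the scatter), and losing the chloro gives a number 3 percentage points higher from compound 1 to compound 4 (within the scatter). Within the data shown here, the earlier compounds showed only that one group could be exchanged for another on this ring, whereas compound 4 shows that the read-out also stays within the scatter when a group is taken away, though no information is available to explain this lack of change.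

From the compounds shown here alone, all of these comparisons keep at least one chloro or trifluoromethyl on the phenyl ring, so it remains open whether the plain phenyl ring, or one carrying an amine or a carboxylic acid, would move the read-out beyond the scatter. Going by these compounds, it is equally open whether replacing the phenyl ring with a longer alkyl chain would do so, or whether changes elsewhere on the shared core would matter more than those at this position.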